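Adding a second chloro to a chloromethylbenzyl-bearing core

The source may report more compounds than this note shows. Statements on the series, on what has been measured and on what is new or still open speak of the compounds shown alone.

Of the compounds shown here, three have been tested in a functional assay on NCI/ADR-RES cells (Homo sapiens) for cytotoxicity, read by sulforhodamine B assay, with a stated time of 48 h; a higher number here means a weaker inhibitor of growth, a lower number a stronger inhibitor of growth. Compound 1 `ClCc1cccc(Cn2cnc3ncnc(Cl)c32)c1` gives 2750 nM. Compound 2 `ClCc1cccc(Cn2cnc3c(Cl)ncnc32)c1` gives 2450 nM; the difference between the cores of compound 1 and compound 2 is not broken down here. Compound 3 `ClCc1cccc(Cn2cnc3c(Cl)nc(Cl)nc32)c1` gives 2390 nM. From compound 2 to compound 3 the change is chloro in place of hydrogen on an aromatic carbon, and it made a 1.0-fold lower number from compound 2 to compound 3 (0.01 log units; within the scatter).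

Compound 4 `ClCc1cccc(Cn2cnc3nc(Cl)nc(Cl)c32)c1` has not yet been measured. It is made from compound 1 by the same change, (chloro in place of hydrogen on an aromatic carbon), at a place described in the same words. Because the step of a 1.0-fold lower number from compound 2 to compound 3 (0.01 log units; within the scatter) stayed within the scatter, the step of a 1.1-fold lower number from compound 1 to compound 4 (0.02 log units; within the scatter) is expected to be small as well. On that basis compound 4 is estimated to give 2600 nM in this assay, with a likely range from 1500 nM to 4500 nM.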

Compound 4, concentration for 50% growth inhibition: 1540 nM
Estimate against measurement, compound 4: 1.7-fold (0.23 log units) above, and the stated range covers the measured number.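

In this assay, chloro in place of hydrogen on an aromatic carbon between two ring nitrogen atoms gives a 1.8-fold lower number from compound 1 to compound 4 (0.25 log units; within the scatter). Set beside the earlier step, the change behaves alike on the two cores as far as this assay can tell: the same change on two cores in this assay, a 1.0-fold lower number (0.01 log units; within the scatter) from compound 2 to compound 3 and a 1.8-fold lower number (0.25 log units; within the scatter) from compound 1 to compound 4, 1.7-fold (0.24 log units) apart, within the scatter of two such steps

Within the data shown here, this agreement rests on only two pairs of compounds, and neither step stands clear of the scatter, so it does not show that the added chloro truly alters growth inhibition on either core, or that the result would carry over to a third core.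

The compounds shown leave open whether an amine or a methoxy group at this carbon would give a step beyond the scatter. They also leave open whether a hydroxymethyl group in place of the chloromethyl group would change the picture.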